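Dichlorophenyl amides and a methoxycarbonyl swap

The source may report more compounds than this note shows. Statements on the series, on what has been measured and on what is new or still open speak of the compounds shown alone.

Measured in a functional assay on SiHa cells (Homo sapiens) for inhibition; on this read-out lower numbers stand for stronger inhibition and higher numbers for weaker inhibition:
compound 1 `COc1cc(/C=C/C(=O)c2cccc(NC(=O)c3c(Cl)cccc3Cl)c2)ccc1O`: 3.56 ug/mL
compound 2 `COc1cc(/C=C/C(=O)c2cccc(NC(=O)c3ccc(Cl)cc3Cl)c2)ccc1O`: 34.4 ug/mL

Compound 2 holds the higher of the two numbers at 34.4 ug/mL, so it is the weaker inhibitor of the pair. The next entry is compound 3 `COC(=O)C(=O)Nc1cccc(C(=O)/C=C/c2ccc(O)c(OC)c2)c1`, which keeps the shared core and carries methoxycarbonyl in place of 2,4-dichlorophenyl on a carbonyl carbon. Among the compounds with values here, only one measured step bears on this, a 9.7-fold higher number from compound 1 to compound 2 (0.99 log units; beyond the scatter), made at the same carbonyl carbon. It shows that this assay responds to changes there, but it only exchanges one dichlorophenyl for another. Within the data shown here, no measured compound lacks the ring at this place, so the direction remains open. A modest move toward lower numbers is expected, probably not beyond the scatter. The estimated change is a 1.7-fold lower number from compound 2 to compound 3 (0.24 log units; within the scatter). The expected value for compound 3 is 20 ug/mL, with an estimated range of 5 ug/mL to 70 ug/mL.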

Compound 3, half-maximal inhibitory concentration: 7.71 ug/mL
Estimate against measurement, compound 3: 2.6-fold (0.41 log units) above, within the range that was stated.
By their numbers in this assay, from the lowest: compound 1; then compound 3; then compound 2.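

In this assay, a group without a ring is tolerated on this carbonyl carbon: methoxycarbonyl in place of 2,4-dichlorophenyl gives a 4.5-fold lower number from compound 2 to compound 3 (0.65 log units; beyond the scatter). The same replacement of 2,6-dichlorophenyl gives a 2.2-fold higher number from compound 1 to compound 3 (0.34 log units; beyond the scatter), so the ring-free group falls between the two dichlorophenyl amides, and whether removing the ring raises or lowers the number depends on which of them it replaces. Nothing at hand accounts for this order.

Still open, on these data alone, is how an unsubstituted phenyl ring or a monochlorophenyl ring would compare at this carbonyl carbon, which would separate the contribution of the ring from that of its chlorines. Also open, as far as these compounds go, is whether the methyl ester matters, which a carboxylic acid or a primary amide in place of methoxycarbonyl would test.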